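Ester for amide on the pyrrole carbonyl: compound 4 expected

This account rests on a few compounds, and the source may have more. Where it says the series, first, only, none or still open, it means among the compounds named here.

The shared core of compound 1 `CCN(CC)CCCNC(=O)c1ccc(C(CC)(CC)c2ccc(OCC(=O)C(C)(C)C)c(C)c2)n1CC` gives 22 nM in an assay on HL-60 cells for agonist activity at vitamin D3 receptor (Homo sapiens), read by microscopy, with a stated time of 96 h; on this read-out higher numbers stand for an effect only at larger amounts of compound and lower numbers for an effect already at smaller amounts. Compound 2 `CCn1c(C(=O)N(CCC#N)CCC#N)ccc1C(CC)(CC)c1ccc(OCC(=O)C(C)(C)C)c(C)c1` gives 870 nM, and compound 3 `CCN(CC)CCCNC(=O)c1ccc(C(CC)(CC)c2ccc(OCC(O)C(C)(C)C)c(C)c2)n1CC` gives 66 nM. Among these three, compound 3 stands second highest: compound 1 lies nearer, with a 3.0-fold higher number from compound 1 to compound 3 (0.48 log units; beyond the scatter), while compound 2 lies furthest, with a far higher number than compound 3.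

Compound 4 `C#CC(C)OC(=O)c1ccc(C(CC)(CC)c2ccc(OCC(O)C(C)(C)C)c(C)c2)n1CC` differs from compound 3 by (1-methylprop-2-yn-1-yl)oxy in place of (3-(diethylamino)propyl)amino on a carbonyl carbon. For the measured compounds named here, the only measured step at that same position is the one from compound 1 to compound 2, which showed a 40-fold higher number from compound 1 to compound 2 (1.60 log units; beyond the scatter), a large rise once the diethylaminopropyl amide was exchanged. The change to compound 4 is again an exchange of that group, here for an ester, so a large step towards higher numbers in this assay is expected, though its exact size cannot be taken from one precedent. Compound 4 is therefore estimated at 1300 nM, within 300 nM to 6000 nM, which means a step of a 20-fold higher number from compound 3 to compound 4 (1.29 log units; beyond the scatter) is expected.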

Compound 4, half-maximal effective concentration: 200 nM
The estimate for compound 4 lay 6.5-fold (0.81 log units) above the measured number; the measured number lies below the stated range.
By their numbers in this assay, from the lowest: compound 1; then compound 3; then compound 4; then compound 2.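

In this assay, (1-methylprop-2-yn-1-yl)oxy in place of (3-(diethylamino)propyl)amino on the carbonyl carbon gives a 3.0-fold higher number from compound 3 to compound 4 (0.48 log units; beyond the scatter), so losing that group need not cost as much as the earlier exchange at this position, a 40-fold higher number from compound 1 to compound 2 (1.60 log units; beyond the scatter). The size of a step here therefore varies among the listed pairs, although the two pairs differ both in the entering group and in the rest of the molecule: compound 1 and compound 2 carry (tert-butyl)carbonyl, whereas compound 3 and compound 4 carry 1-hydroxy-2,2-dimethylpropyl. No measurement offered here accounts for the gap between these two steps.

From the compounds shown here alone, it remains open whether the ester link or the alkyne-bearing chain sets the size of the new step. A carboxylic acid or a plain ethyl ester on the same carbonyl carbon would help to separate the two.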